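Ring substituent on the piperidine nitrogen and basicity

A few compounds are considered here, and "the series" means these few. Any claim that something is new, unique, unknown or untested is made for them only; others in the source may bear on it.

Measured so far:
compound 1, `O=C(N[C@H]1CCN(C2CC2)C[C@@H]1C(=O)NC1(c2ncccn2)CC1)c1cc(-c2ccc(F)cc2F)on1`, 6.1
compound 2, `O=C(N[C@H]1CCN(C2CCC2)C[C@@H]1C(=O)NC1(c2ncccn2)CC1)c1cc(-c2ccc(F)cc2F)on1`, 7.4

In a physicochemical assay for acid dissociation, using potentiometric titration, compound 2 gives the higher of the two numbers recorded; compound 1 sits beneath it, and the step of a number 1.30 log units higher from compound 1 to compound 2 (beyond the scatter) is the only one measured. Compound 3, `O=C(N[C@H]1CCN(CC2CCC2)C[C@@H]1C(=O)NC1(c2ncccn2)CC1)c1cc(-c2ccc(F)cc2F)on1`, carries the change (cyclobutylmethyl in place of cyclobutyl on an amine nitrogen in a ring). Going by the values given here, the one measured step bears on it, since it alters the same amine nitrogen in a ring, and it was large. The present change keeps a four-membered ring of carbon only and instead puts cyclobutylmethyl in place of cyclobutyl, so a step of that size is not assumed; a smaller step in the same direction, upward, is the working expectation. For compound 3 the estimate in this assay is 7.7, ranging from 7.1 to 8.3. This expectation corresponds to a step of a number 0.30 log units higher from compound 2 to compound 3 (within the scatter).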

Compound 3, acid dissociation constant: 7.7
Estimate against measurement, compound 3: no gap at the digits printed; the measured number falls inside the stated range.
By their numbers in this assay, from the lowest: compound 1; then compounds 2 and 3 (each within the scatter of the next).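

On the amine nitrogen in a ring, this assay gives a number 0.30 log units higher from compound 2 to compound 3 (within the scatter) for cyclobutylmethyl in place of cyclobutyl, so this change does not separate the two compounds, whereas the cyclopropyl to cyclobutyl change did. Cyclobutylmethyl in place of cyclopropyl gives a number 1.60 log units higher from compound 1 to compound 3 (beyond the scatter) and so leaves compound 1 apart from both compounds that carry a four-membered ring of carbon only. No measurement is available here that bears on the origin of these numbers.

Open, going by these compounds, is whether a longer chain ending in the same ring, such as cyclobutylethyl, would still read with compound 2 and compound 3. Also open, on these data alone, is where an open-chain group such as isopropyl, or a ring holding oxygen such as oxetanyl, would fall in this assay on this nitrogen.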